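Benzyl Replaced by 4-Fluorophenyl on the Nitrogen

The source may hold more compounds than are shown below. What is called first, only, known or untested is meant among the compounds shown, and "the series" means these compounds.

Three compounds share one core. Compound 1 `Cc1ccccc1NC(=S)N/N=C/c1ccc2ccccc2n1` gives 73200 nM in a functional assay on HL-60 cells (Homo sapiens) for antiproliferative activity, read by sulforhodamine B assay, with a stated time of 72 h; on this read-out lower numbers stand for stronger inhibition and higher numbers for weaker inhibition. Compound 2 `Fc1ccccc1NC(=S)N/N=C/c1ccc2ccccc2n1` reaches only a limit of the assay, > 100000 nM, in this assay. Compound 3 `S=C(NCc1ccccc1)N/N=C/c1ccc2ccccc2n1` gives 21900 nM in this assay, the lowest of the two numbers; its nearest neighbour is compound 1, as a 3.3-fold lower number from compound 1 to compound 3 (0.52 log units; beyond the scatter) shows. Compound 4 `Fc1ccc(NC(=S)N/N=C/c2ccc3ccccc3n2)cc1` differs from compound 3 by 4-fluorophenyl in place of benzyl on an amide-type nitrogen. Among the measured compounds shown here, two measured steps bear on this change: a 3.3-fold lower number from compound 1 to compound 3 (0.52 log units; beyond the scatter) and an at least 4.5-fold lower number from compound 2 to compound 3 (0.65 log units; beyond the scatter), where benzyl lowered the number. Returning from benzyl to an aromatic group is therefore expected to raise the number, the estimated step being a 3.0-fold higher number from compound 3 to compound 4 (0.47 log units; beyond the scatter), although neither measured aromatic group is 4-fluorophenyl. Compound 4 is thus estimated at 65000 nM, within 25000 nM to 160000 nM.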

Compound 4, half-maximal inhibitory concentration: 17000 nM
Estimate against measurement, compound 4: 3.8-fold (0.58 log units) above, and the stated range ends above it.
By their numbers in this assay, from the lowest: compounds 4 and 3 (each within the scatter of the next); then compound 1. At a limit, above all of these: compound 2.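

In this assay, an aromatic ring directly on the amide-type nitrogen does not by itself cost activity, as a 1.3-fold lower number from compound 3 to compound 4 (0.11 log units; within the scatter) shows: 4-fluorophenyl and benzyl cannot be told apart here. The choice of aromatic group does matter, with an at least 5.8-fold lower number from compound 2 to compound 4 (0.76 log units; beyond the scatter) for 4-fluorophenyl in place of 2-fluorophenyl and a 4.3-fold lower number from compound 1 to compound 4 (0.63 log units; beyond the scatter) for 4-fluorophenyl in place of 2-methylphenyl. The first of these steps is only a floor, since compound 2 stands at a limit, not a number: the limit of > 100000 nM in this assay, at which 1 of the 4 values shown sits.

Left open is how plain phenyl would compare with 4-fluorophenyl on this nitrogen. Also open, as far as these compounds go, is whether an amine on the aromatic ring, or a longer chain in place of benzyl, would move the number.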